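A few compounds are considered here, and "the series" means these few. Any claim that something is new, unique, unknown or untested is made for them only; others in the source may bear on it.

For the measured compounds named here, compound 1 `C/C=C/C(=O)N(Cc1cccc(O)c1)c1cc(OC)c(OC)c(OC)c1` gives 6700 nM in a functional assay on HCT-116 cells (Homo sapiens) for inhibition, read by MTT assay, with a stated time of 48 h (on this read-out higher numbers stand for weaker inhibition and lower numbers for stronger inhibition), the lowest of the two numbers measured so far. Compound 2 `COc1cc(NCc2cccc(O)c2)cc(OC)c1OC` gives 67700 nM in this assay, and the step of a 10-fold higher number from compound 1 to compound 2 (1.00 log units; beyond the scatter) comes from a hydrogen in place of the (prop-1-en-1-yl)carbonyl on the nitrogen. Compound 3 `C/C=C/C(=O)N(Cc1ccc(OC)c(Cl)c1)c1cc(OC)c(OC)c(OC)c1` keeps that group and differs from compound 1 only by 3-chloro-4-methoxyphenyl in place of 3-hydroxyphenyl on a saturated chain carbon bound to an amide-type nitrogen. Going by the values given here, no measured step touches this part of the structure, so nothing points to a direction, and a step within the scatter is what is expected: a 1.2-fold higher number from compound 1 to compound 3 (0.08 log units; within the scatter). Compound 3 is therefore estimated at 8000 nM, within 2500 nM to 25000 nM.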

Compound 3, half-maximal inhibitory concentration: 1420 nM
Beside the measured number, compound 3's estimate is 5.6-fold (0.75 log units) above it, and the stated range ends above it.
By their numbers in this assay, from the lowest: compound 3; then compound 1; then compound 2.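

In this assay the step of a 4.7-fold lower number from compound 1 to compound 3 (0.67 log units; beyond the scatter) shows that the ring on the saturated chain carbon bound to an amide-type nitrogen also affects the number, which the earlier step on the nitrogen could not show. The 3-hydroxyphenyl group is therefore not needed for this level of inhibition. No measurement here explains the gain. The change removes the hydroxyl and adds chlorine and methoxy together, leaving their separate contributions unresolved. A ring carrying only the chlorine, only the methoxy or an amine remains an open comparison.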